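Fluoro to Chloro on the Benzylsulfanyl Arm

This account rests on a few compounds, and the source may have more. Where it says the series, first, only, none or still open, it means among the compounds named here.

Compound 1 `CSc1ccc(/C=C(/SCc2ccc(Cl)cc2)C(=O)c2ccc(C(=O)O)cc2)cc1`: > 100000 nM, a limit of the assay.
Compound 2 `CN(C)c1ccc(/C=C(/SCc2ccc(Cl)cc2)C(=O)c2ccc([N+](=O)[O-])cc2)cc1`: > 100000 nM, a limit of the assay.
Compound 3 `CN(C)c1ccc(/C=C(/SCc2ccc(F)cc2)C(=O)c2ccc(C(=O)O)cc2)cc1`: 10000 nM.

In a functional assay on DU-145 cells (Homo sapiens) for inhibition, read by trypan blue exclusion, with a stated time of 96 h (a lower number here means a stronger inhibitor of growth, a higher number a weaker inhibitor of growth), compound 1 reaches only the limit > 100000 nM and gives no number. Compound 2 likewise stops at the limit > 100000 nM in this assay. Going by the values given here, compound 3 is the only member of the set with a measured value, 10000 nM in this assay, so it stands alone as the single point of reference; the other two sit at the limit of > 100000 nM in this assay, at which 2 of the 3 values shown sit.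

Compound 4 `CN(C)c1ccc(/C=C(/SCc2ccc(Cl)cc2)C(=O)c2ccc(C(=O)O)cc2)cc1` differs from compound 3 in one place: chloro in place of fluoro on an aromatic carbon. Among the compounds with values here, no measured pair in the set shows what this exchange does in this assay, so the expectation rests on compound 3 alone. The change is small in count, and no step beyond the usual scatter is expected from it.

Compound 4 is therefore estimated near compound 3, at 8000 nM, between 2500 nM and 30000 nM. The step from compound 3 to compound 4 is expected to be a 1.3-fold lower number from compound 3 to compound 4 (0.10 log units; within the scatter), within the scatter.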

Compound 4, concentration for 50% growth inhibition: 1000 nM
The estimate for compound 4 lay 8.0-fold (0.90 log units) above the measured number, outside the stated range (below it).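

In this assay, the halogen on the benzylsulfanyl arm proves to matter: the change from (4-fluorobenzyl)sulfanyl to (4-chlorobenzyl)sulfanyl gives a 10-fold lower number from compound 3 to compound 4 (1.00 log units; beyond the scatter). With chloro on that arm, the other two exchanged groups also count, as carboxy in place of nitro gives an at least 100-fold lower number from compound 2 to compound 4 (2.00 log units; beyond the scatter), and dimethylamino in place of methylsulfanyl gives an at least 100-fold lower number from compound 1 to compound 4 (2.00 log units; beyond the scatter). Those two larger steps start from a limit of the assay and not from a number: the limit of > 100000 nM in this assay, at which 2 of the 4 values shown sit.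

The compounds shown leave open how bromo, methyl or trifluoromethyl would read at this place on the aromatic ring, and so whether the step belongs to chloro alone. They also leave open what an amide or a methyl ester would give in place of the carboxy group.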